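This account rests on a few compounds, and the source may have more. Where it says the series, first, only, none or still open, it means among the compounds named here.

The measured compounds:
compound 1, `CCC(C)C1NC(=O)N(C2CCCCC2)C1=O`, > 100 ug/mL
compound 2, `CC(C)C(NC(=O)n1nnc2ccccc21)C(=O)NC1CCCC1`, > 200 ug/mL
compound 3, `CC(C)C1NC(=O)N(C2CCCCC2)C1=O`, >= 100 ug/mL

In a functional assay on HEL cells (Homo sapiens) for cytotoxicity (a higher number here means that more compound is tolerated, a lower number that less compound is tolerated), compound 3 gives >= 100 ug/mL, which is a limit of the assay and not a number. Compound 1 gives > 100 ug/mL, again a limit. The change between them, (methyl in place of hydrogen on a saturated chain carbon, two bonds along the chain from a saturated ring carbon), therefore makes a step that the two limits leave unreadable from compound 3 to compound 1. Compound 2, built on a different core, gives > 200 ug/mL, also a limit. The difference between the core of compound 2 and that of compound 3 is not broken down here. Compound 4, `CCC(C)C(NC(=O)n1nnc2ccccc21)C(=O)NC1CCCC1`, has not been measured in this assay; it differs from compound 2 by methyl in place of hydrogen on a saturated chain carbon, three bonds along the chain from an amide-type nitrogen and a carbonyl carbon. This is the same kind of change as that from compound 3 to compound 1, but the surroundings differ: in the earlier pair the methyl enters two bonds along the chain from a saturated ring carbon, here three bonds along the chain from an amide-type nitrogen and a carbonyl carbon. Both values of the earlier pair sit at a limit, the limit of > 100 ug/mL in this assay, at which 1 of the 3 values shown sits, and (the limit of >= 100 ug/mL in this assay, at which 1 of the 3 values shown sits), so that step has no readable size. The expectation for compound 4 rests on compound 2 sitting at the limit of > 200 ug/mL in this assay, at which 1 of the 3 values shown sits. The step from compound 2 to compound 4 is expected to be a number no higher from compound 2 to compound 4 (the limit leaves the size open). Compound 4 is thus estimated at 200 ug/mL, between 100 ug/mL and 300 ug/mL.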

Compound 4, minimum cytotoxic concentration: >= 80 ug/mL
Compound 4 was reported as a limit; the forecaster's own chance of this, stated with the estimate: 80%; the middle value does not contradict the limit.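

In this assay compound 2 and compound 4 are both reported only as limits and not as numbers, so the step between them, methyl in place of hydrogen, cannot be read. The compounds shown leave open whether this methyl changes the tolerated concentration at all, in this pair or between compound 3 and compound 1.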